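This account rests on a few compounds, and the source may have more. Where it says the series, first, only, none or still open, it means among the compounds named here.

Measured compounds in the series so far:

- compound 1, `Cc1cc(C(/C=C2\OC(=O)NC2=O)C(C)C)c(=O)[nH]c1-c1ccc2cccc(F)c2c1`: in an assay on membranes from Chem-1 cells for displacement of a labelled ligand from prostaglandin E2 receptor EP3 subtype (Homo sapiens), read by scintillation counting, with a stated time of 2 h (a higher number here means a weaker inhibitor, a lower number a stronger inhibitor), compound 1 gives 23 nM
- compound 2, `CC(C)/C(=C1/OC(=O)NC1=O)c1ccc(-c2ccc3cccc(F)c3c2)[nH]c1=O`: in this assay compound 2 gives 140 nM

Compound 1 holds the lowest number of the two in this assay. Compound 2 stands at a higher number, and the gap between the two lies beyond the usual scatter of this kind of measurement. Compound 1 and compound 2 differ from each other in more than one place, so no single structural step can be read from that pair; the two values are simply noted side by side.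

Compound 3, `CC(C)C(/C=C1\OC(=O)NC1=O)c1cc(Cl)c(-c2ccc3cccc(F)c3c2)[nH]c1=O`, has not yet been measured in this assay. It differs from compound 1 in one place only: chloro in place of methyl on an aromatic carbon. Going by the values given here, no pair isolates this exchange, so the expectation for compound 3 rests on compound 1 alone, with nothing in the data pointing to a shift in either direction. The step of a 1.2-fold lower number from compound 1 to compound 3 (0.06 log units; within the scatter) is therefore expected to stay within the scatter. Compound 3 is estimated at 20 nM in this assay, with a range from 7 nM to 60 nM to be confirmed when the number arrives.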

Compound 3, inhibition constant in the prostaglandin E2 receptor EP3 subtype assay: 380 nM
Estimate against measurement, compound 3: 19-fold (1.28 log units) below; measured number above the stated range.
By their numbers in the prostaglandin E2 receptor EP3 subtype assay, from the lowest: compound 1; then compound 2; then compound 3.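

The exchange of methyl for chloro on this aromatic carbon, ortho to a large group and two atoms from the ring nitrogen, gives in the prostaglandin E2 receptor EP3 subtype assay a 17-fold higher number from compound 1 to compound 3 (1.22 log units; beyond the scatter). This position is therefore sensitive to a change of a single heavy atom, and in this pair methyl is clearly preferred over chloro, a sensitivity that compounds 1 and 2 alone could not reveal. In a physicochemical assay for solubility, measured as kinetic solubility, at pH 2 (a higher number here means a more soluble compound, a lower number a less soluble compound), compound 1 gives 39400 nM and compound 3 gives 3200 nM. The same pair also shows that chloro at this position comes with a measured cost in solubility, so the exchange is unfavourable on both read-outs: the measured solubility of compound 1, 39400 nM, and of compound 3, 3200 nM, a 12-fold lower number (1.09 log units; beyond the scatter)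

A single exchange cannot separate what is lost with methyl from what enters with chloro, and the pair does not show whether the two shifts are connected. Also open, from the compounds shown here alone, is how the position responds to other groups in this place, such as fluoro, ethyl, methoxy or an amine, and whether any of them can match methyl on both read-outs.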